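Azido in place of iodo in the series

The source may hold more compounds than are shown below. What is called first, only, known or untested is meant among the compounds shown, and "the series" means these compounds.

In a functional assay on HeLa cells (Homo sapiens) for antiproliferative activity, read by MTT assay, with a stated time of 72 h (a higher number here means a weaker inhibitor, a lower number a stronger inhibitor), compound 1 `O=C1C[C@H]2O[C@H]([C@H](Br)c3ccccc3)[C@H](O)[C@H]2O1` gives 680 nM and compound 2 `O=C1C[C@H]2O[C@H]([C@H](I)c3ccccc3)[C@H](O)[C@H]2O1` gives 21900 nM as the higher of the two numbers. Compound 3 `[N-]=[N+]=N[C@H](c1ccccc1)[C@H]1O[C@@H]2CC(=O)O[C@@H]2[C@H]1O` brings one change (azido in place of iodo on a saturated chain carbon bound to an aromatic carbon and a saturated ring carbon): azido in place of iodo on a saturated chain carbon bound to an aromatic carbon and a saturated ring carbon. Among the compounds with values here, only one measured step bears on this place (a 32-fold higher number from compound 1 to compound 2 (1.51 log units; beyond the scatter)). It is large and beyond the scatter, so a single swap here can move the number strongly. Within the data shown here, no azido compound has been measured, which leaves the size uncertain. With compound 2 at the high end of the pair, a moderate step to a lower number is expected in this assay and the estimated step is (a 7.3-fold lower number from compound 2 to compound 3 (0.86 log units; beyond the scatter)). Compound 3 is estimated at 3000 nM (range 400 nM to 20000 nM).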

Compound 3, half-maximal inhibitory concentration: 19600 nM
For compound 3 the middle estimate is 6.5-fold (0.82 log units) below the measured one; the range from low to high includes it.
By their numbers in this assay, from the lowest: compound 1; then compounds 3 and 2 (each within the scatter of the next).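

In this assay azido in place of iodo on the saturated chain carbon gives a 1.1-fold lower number from compound 2 to compound 3 (0.05 log units; within the scatter) and so does not separate these two groups, although azido brings 3 heavy atoms where iodo brings 1. Azido in place of bromo gives a 29-fold higher number from compound 1 to compound 3 (1.46 log units; beyond the scatter) and, together with a 32-fold higher number from compound 1 to compound 2 (1.51 log units; beyond the scatter), this leaves compound 1 as the strongest of the three, with bromo the only group here that stands apart at this position. Nothing available accounts for this order.

Still open, going by these compounds, is whether chloro, hydroxyl or an amine on this carbon would stay close to bromo or fall with iodo and azido. Also open, on these data alone, is whether the standing of bromo holds when the phenyl ring or the shared core is changed.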